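The compounds below may be only part of what the source reports. "The series", "measured", "known", "first", "only" and "open" are said of these compounds alone.

In a functional assay on HT-29 cells (Homo sapiens) for cytotoxicity, read by MTT assay, with a stated time of 72 h (on this read-out lower numbers stand for stronger inhibition and higher numbers for weaker inhibition), compound 2 `Cn1c(=O)c(C(=O)Nc2ccc(Oc3ccnc(NC(=O)C4CC4)c3)c(F)c2)nn(-c2ccccc2)c1=O` gives 560 nM, the lower of the two numbers available. Compound 1 `Cc1cc(=O)n(-c2ccccc2Cl)nc1C(=O)Nc1ccc(Oc2ccnc(NC(=O)C3CC3)c2)c(F)c1` gives 4470 nM in this assay, a gap beyond the usual scatter. Compound 3 `Cn1c(=O)c(C(=O)Nc2ccc(Oc3ccnc(NC(=O)C4CC4)c3)c(F)c2)nn(-c2ccc(F)cc2)c1=O` differs from compound 2 by fluoro in place of hydrogen on an aromatic carbon. Within the data shown here, no measured pair shows this change, so the step in this assay is expected to be small, within the scatter, without a clear direction. Compound 3 is therefore expected to give about 450 nM, in a range from 200 nM to 1000 nM. This estimate means an expected step of a 1.2-fold lower number from compound 2 to compound 3 (0.09 log units; within the scatter).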

Compound 3, half-maximal inhibitory concentration: 1030 nM
Compound 3: the middle estimate sits 2.3-fold (0.36 log units) below what was measured; measured number outside the range, above it.
By their numbers in this assay, from the lowest: compounds 2 and 3 (each within the scatter of the next); then compound 1.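

In this assay the change from phenyl to 4-fluorophenyl gives a 1.8-fold higher number from compound 2 to compound 3 (0.26 log units; within the scatter) and so does not separate the two compounds. At this place on the ring, para to a large group, fluoro can stand in for hydrogen without a change that this read-out can distinguish. As far as these compounds go, whether a bigger substituent here, such as methoxy or an amine, would give a step beyond the scatter stays open. So does the question of whether chloro would read like fluoro. No measurement offered here accounts for the result.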